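The compounds below may be only part of what the source reports. "The series", "measured", "known", "first", "only" and "open" are said of these compounds alone.

Compound 1, `OC(CCn1nc2c(Br)c(Br)c(Br)c(Br)c2n1)c1cccc(Br)c1`, gives 54% in a functional assay on CCRF-CEM cells (Homo sapiens) for antiproliferative activity, read by MTT assay, with a stated time of 24 h, tested at 50 uM; a lower number here means a stronger effect, a higher number a weaker effect of the compound at the concentration tested.
Compound 2, `COc1cccc(C(O)CCn2nc3c(Br)c(Br)c(Br)c(Br)c3n2)c1`, gives 58% in this assay.
Compound 3, `C[C@@H](O)CCn1nc2c(Br)c(Br)c(Br)c(Br)c2n1`, gives 69% in this assay.

Among these three numbers compound 3 stands highest: its nearest neighbour is compound 2, whose number is lower by a margin beyond the scatter, and its furthest is compound 1, whose number is lower by a larger margin, also beyond the scatter. Among the measured compounds shown here, the only step between measured compounds that differ in one place is a number 4 percentage points higher from compound 1 to compound 2 (within the scatter), a change of methoxy in place of bromo on an aromatic carbon.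

Compound 4, `C[C@H](O)CCn1nc2c(Br)c(Br)c(Br)c(Br)c2n1`, has not yet been measured in this assay. It differs from compound 3 as follows: the two compounds have the same atoms and bonds and differ only in configuration as drawn: 1 of 1 stereo elements differ; a stereocentre at a saturated chain carbon is drawn R in compound 3 and S in compound 4. For the measured compounds named here, the one measured step concerns a group on the aromatic ring and says nothing about a change of configuration at the saturated chain carbon; no measured pair in this set bears directly on such a change. Going by the values given here, with no step of this kind to draw on, the expectation is that the number for compound 4 stays close to that of compound 3, with an estimated step of a number 2 percentage points lower from compound 3 to compound 4 (within the scatter), not beyond the scatter. Compound 4 is therefore estimated at 67%, expected between 54% and 80%.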

Compound 4, a percentage reported as activity, at one concentration (the size of the read-out at that concentration, not a potency): 86%
Beside the measured number, compound 4's estimate is 19 percentage points below it; the measured number lies above the stated range.
By their numbers in this assay, from the lowest: compounds 1 and 2 (each within the scatter of the next); then compound 3; then compound 4.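

In this assay, the change of configuration at the saturated chain carbon, from R to S as drawn, brings a number 17 percentage points higher from compound 3 to compound 4 (beyond the scatter), so at the concentration tested the S form has the weaker effect. The earlier compounds shown here offered only a step on an aromatic ring, which stayed within the scatter, and gave no indication of whether the drawn configuration at this chain carbon mattered; this pair shows that it does, even with the atoms and bonds unchanged. The step can be assigned to this stereocentre alone, because nothing else separates the two structures: the fact that compounds 3 and 4 differ only in the configuration as drawn

The compounds shown leave open whether configuration counts for as much when the chain also carries an aromatic ring, as in compound 1 and compound 2, neither of which has its configuration drawn. They also leave open whether the difference between the two forms would persist with an amine in place of the hydroxyl at this stereocentre, or with a longer chain linking that carbon to the shared core.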